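Trichloromethyl in Place of Nitro: What Compound 4 Should Give

A few compounds are considered here, and "the series" means these few. Any claim that something is new, unique, unknown or untested is made for them only; others in the source may bear on it.

Four compounds share one core. In a physicochemical assay for acid dissociation, compound 1 `CC(=O)Nc1ccc(OC(=S)Nc2ccc(Nc3ccc(C(Cl)(Cl)Cl)cc3)cc2)cc1` gives 9.01. Compound 2 `Oc1ccc(OC(=S)Nc2ccc(Nc3ccc(C(F)(F)F)cc3)cc2)cc1` gives 9.23 in this assay, and compound 3 `O=[N+]([O-])c1ccc(Nc2ccc(NC(=S)Oc3ccc(O)cc3)cc2)cc1` gives 9.22. Compound 3 stands second highest of the three numbers, with compound 2 nearest and compound 1 furthest, both differences within the scatter. Compound 4 `Oc1ccc(OC(=S)Nc2ccc(Nc3ccc(C(Cl)(Cl)Cl)cc3)cc2)cc1` has not been measured; it differs from compound 3 by trichloromethyl in place of nitro on an aromatic carbon. Within the data shown here, the one measured step at this position, a number 0.01 log units lower from compound 2 to compound 3 (within the scatter), lay within the scatter. Compound 1 also carries trichloromethyl, and its value sits within the scatter of compound 3. The step of a number 0.02 log units lower from compound 3 to compound 4 (within the scatter) is therefore expected to stay within the scatter. Compound 4 is estimated at 9.2, between 8.9 and 9.5.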

Compound 4, acid dissociation constant: 9.23
Estimate against measurement, compound 4: 0.03 log units below; low and high end bracket the measured number.
By their numbers in this assay, from the lowest: compounds 1, 3, 2 and 4 (each within the scatter of the next).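

In this assay, trichloromethyl in place of nitro gives a number 0.01 log units higher from compound 3 to compound 4 (within the scatter), and trichloromethyl in place of trifluoromethyl gives no change at the digits printed from compound 2 to compound 4 (within the scatter), so nitro, trifluoromethyl and trichloromethyl on this aromatic carbon all give values within the scatter of one another. A second place on the core now has a step as well: hydroxy in place of acetamido gives a number 0.22 log units higher from compound 1 to compound 4 (within the scatter). Nothing available bears on the reason for these values. The compounds shown leave open whether an amine or a carboxylic acid on this aromatic carbon would also stay within the scatter.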